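Aryl Swap on the Ring Nitrogen: Estimating Compound 4

The source may hold more compounds than are shown below. What is called first, only, known or untested is meant among the compounds shown, and "the series" means these compounds.

Three compounds have been measured in a functional assay on CHO cells with adenosine receptor A1 (Homo sapiens) as the target, read by cAMP accumulation and immunoassay, with a stated time of 6 min, tested at 10 uM; on this read-out higher numbers stand for a weaker effect at the one concentration tested and lower numbers for a stronger effect:

Compound 1 `Nc1scc(CN2CCN(c3cccc(Cl)c3Cl)CC2)c1C(=O)c1ccc(Cl)cc1`: -77%
Compound 2 `Nc1scc(CN2CCN(c3cc(Cl)cc(Cl)c3)CC2)c1C(=O)c1ccc(Cl)cc1`: -74%
Compound 3 `Nc1scc(CN2CCN(C3CCCCCC3)CC2)c1C(=O)c1ccc(Cl)cc1`: -25%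

Compound 1 stands at the low end of these three numbers, but compound 2 cannot be told apart from it, since a number 3 percentage points higher from compound 1 to compound 2 (within the scatter) lies within the scatter. Compound 3 sits far higher, as a number 52 percentage points higher from compound 1 to compound 3 (beyond the scatter) and a number 49 percentage points higher from compound 2 to compound 3 (beyond the scatter) show. Compound 4 `Nc1scc(CN2CCN(c3cccc(F)c3)CC2)c1C(=O)c1ccc(Cl)cc1` is not yet measured; it differs from compound 1 in one place: 3-fluorophenyl in place of 2,3-dichlorophenyl on an amine nitrogen in a ring. The two large steps came from replacing an aromatic ring with cycloheptyl, whereas compound 4 keeps an aromatic ring there. Going from two chlorines to one fluorine has no measured counterpart, so only a modest rise is expected, a number 17 percentage points higher from compound 1 to compound 4 (beyond the scatter). Compound 4 is estimated at -60%, between -85% and -30%.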

Compound 4, a percentage reported as activity, at one concentration (the size of the read-out at that concentration, not a potency): -82%
Estimate against measurement, compound 4: 22 percentage points above; measured number inside the range.
By their numbers in this assay, from the lowest: compounds 4, 1 and 2 (each within the scatter of the next); then compound 3.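

In this assay the 3-fluorophenyl group serves as well as either dichlorophenyl group, as a number 5 percentage points lower from compound 1 to compound 4 (within the scatter) and a number 8 percentage points lower from compound 2 to compound 4 (within the scatter) leave compound 1, compound 2 and compound 4 impossible to tell apart. A second chlorine is therefore not needed at this position, and a single fluorine is enough, while the large gap to the cycloheptyl compound remains, with a number 57 percentage points lower from compound 3 to compound 4 (beyond the scatter) marking it. No available measurement explains why these aromatic rings behave alike. On these data alone, whether unsubstituted phenyl or 3-methoxyphenyl would hold this level remains open, as does whether cyclohexyl would differ from cycloheptyl.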